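A methyl step in a series at the assay limit

This account rests on a few compounds, and the source may have more. Where it says the series, first, only, none or still open, it means among the compounds named here.

Compound 1 `Nc1cccc(Nc2cc(Cl)cc(Cl)c2)n1` and compound 2 `Nc1ccnc(Nc2cc(Cl)cc(Cl)c2)c1` are close relatives. In an assay on cells for inhibition of S-adenosylmethionine decarboxylase proenzyme (Homo sapiens), read by mass spectrometry, at pH 7.2 (a higher number here means a weaker inhibitor, a lower number a stronger inhibitor), compound 1 gives only a limit, > 180000 nM. In this assay compound 2 likewise gives only a limit, > 180000 nM. Both values sit at the limit of > 180000 nM in this assay, at which 2 of the 2 values shown sit, so compound 2 stands at the edge of what the numbers shown can tell. Compound 3 `Cc1cc(N)cc(Nc2cc(Cl)cc(Cl)c2)n1` differs from compound 2 by methyl in place of hydrogen on an aromatic carbon. Among the compounds with values here, no measured step of this kind exists, and for compound 3 the step that the limit leaves unreadable from compound 2 to compound 3 is expected to stay within the scatter, most likely again as a limit. Compound 3 is estimated at 200000 nM, within 50000 nM to 800000 nM.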

Compound 3, half-maximal inhibitory concentration: > 180000 nM
Compound 3 ended at the assay's limit (the forecaster's own chance of this, stated with the estimate: 85%); the middle value lies beyond the limit too.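

No step can be read from compound 2 to compound 3, as both values are only limits: the limit of > 180000 nM in this assay, at which 3 of the 3 values shown sit.

As far as these compounds go, whether methyl in place of hydrogen on an aromatic carbon alters inhibition at all remains open.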